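Piperidine Variants on a Shared Core: Tolerability Before Measurement

This account rests on a few compounds, and the source may have more. Where it says the series, first, only, none or still open, it means among the compounds named here.

Measured so far:
compound 1, `CCCN(C)c1nn(CCC(C)C)c(=O)c(C2=NS(=O)(=O)c3cc(NS(C)(=O)=O)ccc3N2)c1O`: > 1000 nM
compound 2, `CC(C)CCn1nc(N2CCCCC2)c(O)c(C2=NS(=O)(=O)c3cc(NS(C)(=O)=O)ccc3N2)c1=O`: > 33000 nM

In an ADME assay on Huh-7 cells (Homo sapiens) for cytotoxicity, with a stated time of 72 h (a lower number here means that less compound is tolerated, a higher number that more compound is tolerated), compound 1 gives > 1000 nM, which is a limit of the assay rather than a number. Compound 2 gives in this assay > 33000 nM, again a limit. Where compound 1 stands therefore rests on one limit alone, and the single step touching it, a step that the two limits leave unreadable from compound 1 to compound 2, cannot be read in size or direction, as the limit of > 1000 nM in this assay, at which 1 of the 2 values shown sits, and the limit of > 33000 nM in this assay, at which 1 of the 2 values shown sits, show.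

Compound 3, `CC(C)CCn1nc(N2CCCCC2C)c(O)c(C2=NS(=O)(=O)c3cc(NS(C)(=O)=O)ccc3N2)c1=O`, differs from compound 1 by 2-methylpiperidin-1-yl in place of methyl(propyl)amino on an aromatic carbon. Within the data shown here, the one measured step that bears on this change is a step that the two limits leave unreadable from compound 1 to compound 2, and it gives no usable size. No step beyond the scatter in this assay can therefore be expected with any confidence, and a further limit is the most likely outcome. Compound 3 is estimated at 30000 nM, within a range from 5000 nM to 100000 nM, which as an expected step means a step that the limit leaves unreadable from compound 1 to compound 3.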

Compound 3, half-maximal cytotoxic concentration: > 10000 nM
Compound 3 was reported as a limit; the forecaster's own chance of this, stated with the estimate: 75%; the middle value does not contradict the limit.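

In this assay compound 3 gives > 10000 nM, which is a limit. Among these compounds, compound 1 and compound 2 are limits too, so no step among the three can be read. Left open is whether 2-methylpiperidin-1-yl, piperidin-1-yl or methyl(propyl)amino differ at all in how much compound is tolerated.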